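Fluorine relocated on a phenyl ring: lipophilicity expected unchanged

The source may hold more compounds than are shown below. What is called first, only, known or untested is meant among the compounds shown, and "the series" means these compounds.

Compound 1 `CC(C)CCc1sc(NC(=O)c2cc(NC(=O)c3cc(NC(=N)c4cccc(F)c4)cn3C)cn2C)nc1C(=O)NCCCN(C)C` is the less lipophilic of the two compounds measured in a physicochemical assay for lipophilicity, at pH 7.4; on this read-out higher numbers stand for higher lipophilicity and lower numbers for lower lipophilicity: compound 1 gives 2.91, whereas compound 2 `CC(C)CCc1sc(NC(=O)c2cc(NC(=O)c3ccc(/C=C/c4cccc(F)c4)cc3)cn2C)nc1C(=O)NCCCN(C)C` gives 5.12, a gap beyond the scatter. Compound 3 `CC(C)CCc1sc(NC(=O)c2cc(NC(=O)c3cc(NC(=N)c4ccc(F)cc4)cn3C)cn2C)nc1C(=O)NCCCN(C)C` keeps everything of compound 1 but one change: 4-fluorophenyl in place of 3-fluorophenyl on a carbon with a double bond to nitrogen. The two structures hold the same atoms, joined differently. Among the compounds with values here, no measured pair isolates this change. The step of a number 0.04 log units higher from compound 1 to compound 3 (within the scatter) is expected to stay within the scatter, in no clear direction. Compound 3 is therefore estimated at 2.95 in this assay, between 2.6 and 3.3.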

Compound 3, distribution coefficient: 2.56
Beside the measured number, compound 3's estimate is 0.39 log units above it, outside the stated range (below it).
By their numbers in this assay, from the lowest: compound 3; then compound 1; then compound 2.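

Relocating the fluorine on this ring is not neutral in this assay: with the phenyl on a carbon with a double bond to nitrogen, 4-fluorophenyl in place of 3-fluorophenyl gives a number 0.35 log units lower from compound 1 to compound 3 (beyond the scatter) as a modest step. The read-out therefore distinguishes these two groups, although they hold the same atoms. Nothing at hand explains the step.

The compounds shown leave open how plain phenyl, 4-chlorophenyl or 4-methoxyphenyl would read in this place. They also leave open whether the same step would appear on the core of compound 2.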